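Benzyl to Benzoyl on the Indoline Nitrogen of Compound 1

The source may hold more compounds than are shown below. What is called first, only, known or untested is meant among the compounds shown, and "the series" means these compounds.

The account starts from compound 1 `Cc1ccc(CN2CCc3cc(NC(=O)NCc4ccncc4)ccc32)cc1`, a urea whose saturated bicyclic nitrogen carries a 4-methylbenzyl group. In an assay on HEK293-A cells for activation of Nicotinamide phosphoribosyltransferase (Homo sapiens), tested at 10 uM (a higher number here means a stronger effect of the compound at the concentration tested, a lower number a weaker effect), compound 1 gives "not determined" (no result reported); it stands nowhere on the numbers shown, so its position is open. The two measured compounds share a different core. Compound 2 `O=C(NCc1cn[nH]c1)Nc1ccc2nc(-c3ccccc3)nn2c1` gives 174% in this assay, and compound 3 `O=C(NCc1cnco1)Nc1ccc2nc(-c3ccccc3)nn2c1` gives 138%. Among the compounds with values here, the one measured step, a number 36 percentage points lower from compound 2 to compound 3 (beyond the scatter), concerns the heteroaryl group on the saturated chain carbon bound to the amide-type nitrogen and does not touch the part of the molecule that changes here.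

Compound 4 `Cc1ccc(C(=O)N2CCc3cc(NC(=O)NCc4ccncc4)ccc32)cc1` differs from compound 1 in one place: (4-methylphenyl)carbonyl in place of 4-methylbenzyl on a nitrogen on an aromatic ring in a ring. Within the data shown here, no measured step bears on this change, so neither its size nor its direction can be read from the data. The only anchor is the range the two measured compounds occupy. For compound 4 the expected value in this assay is therefore set near that range, at 125%, with a wide band from 60% to 190%.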

Compound 4, a percentage reported as activity, at one concentration (the size of the read-out at that concentration, not a potency): 62%
Beside the measured number, compound 4's estimate is 63 percentage points above it; low and high end bracket the measured number.
By their numbers in this assay, from the lowest: compound 4; then compound 3; then compound 2.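

No new step can be read between compound 1 and compound 4: in this assay compound 1 has no single number to set against compound 4. No evidence shown bears on this result.

The compounds shown leave open what (4-methylphenyl)carbonyl in place of 4-methylbenzyl does to the read-out.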